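Diethoxymethyl Replaces Acetoxymethyl at the Ring Carbon

A few compounds are considered here, and "the series" means these few. Any claim that something is new, unique, unknown or untested is made for them only; others in the source may bear on it.

Compound 1 `CCCC1=C(C(=O)OCC)C(c2cccc([N+](=O)[O-])c2)C(C(=O)OCC)=C(C)N1` gives 105 nM in a functional assay on HEK293 cells for antagonist activity at Voltage-dependent L-type calcium channel subunit alpha-1D (Rattus norvegicus), read by FLIPR; on this read-out lower numbers stand for stronger inhibition and higher numbers for weaker inhibition.
Compound 2 `CCOC(=O)C1=C(C)NC(CO)=C(C(=O)OCC)C1c1cccc([N+](=O)[O-])c1` gives 45 nM.
Compound 3 `CCOC(=O)C1=C(C)NC(COC(C)=O)=C(C(=O)OCC)C1c1cccc([N+](=O)[O-])c1` gives 37 nM.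

Compound 3 has the lowest of the three numbers. Its gap to compound 2 is small: a 1.2-fold lower number from compound 2 to compound 3 (0.09 log units; within the scatter), so the two cannot be ranked. Against compound 1 the difference is clearer: a 2.8-fold lower number from compound 1 to compound 3 (0.45 log units; beyond the scatter).

Compound 4 `CCOC(=O)C1=C(C)NC(C(OCC)OCC)=C(C(=O)OCC)C1c1cccc([N+](=O)[O-])c1` differs from compound 3 in one place: diethoxymethyl in place of acetoxymethyl on a double-bonded ring carbon. The three measured steps all concern groups at this same ring carbon. Going from ethyl to hydroxymethyl gave a 2.3-fold lower number from compound 1 to compound 2 (0.37 log units; beyond the scatter), to acetoxymethyl a 2.8-fold lower number from compound 1 to compound 3 (0.45 log units; beyond the scatter), and the hydrogen-to-acetyl swap on the oxygen gave a 1.2-fold lower number from compound 2 to compound 3 (0.09 log units; within the scatter). Every change at this position moved the number only modestly, and the acetal of compound 4 keeps the same count of hydrogen-bond acceptors while adding two carbons. A step within or just beyond the scatter is therefore expected, if anything toward a slightly higher number: a 1.4-fold higher number from compound 3 to compound 4 (0.13 log units; within the scatter). Compound 4 is estimated at 50 nM, within 20 nM to 130 nM.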

Compound 4, half-maximal inhibitory concentration: 615 nM
Estimate against measurement, compound 4: 12-fold (1.09 log units) below, outside the stated range (above it).
By their numbers in this assay, from the lowest: compounds 3 and 2 (each within the scatter of the next); then compound 1; then compound 4.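

Within the data shown here, this position is less forgiving than the earlier compounds suggested. In this assay, moving to diethoxymethyl gave a 17-fold higher number from compound 3 to compound 4 (1.22 log units; beyond the scatter) and also a 14-fold higher number from compound 2 to compound 4 (1.14 log units; beyond the scatter) when starting from hydroxymethyl, both large beside the modest steps seen before. Even the propyl group does better, with a 5.9-fold higher number from compound 1 to compound 4 (0.77 log units; beyond the scatter) as the result of its replacement, so among these four groups diethoxymethyl alone gives a higher number than propyl, although acetoxymethyl and diethoxymethyl match in their counts of hydrogen-bond donors and acceptors.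

Nothing measured here bears on why the number rose. The compounds shown also leave open whether a smaller acetal such as dimethoxymethyl, or a group such as aminomethyl, would stay close to compound 3 or rise toward compound 4.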